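A few compounds are considered here, and "the series" means these few. Any claim that something is new, unique, unknown or untested is made for them only; others in the source may bear on it.

Compound 1 `CN1CC(=O)N(Cc2ccc(C(=O)NO)cc2)C1=O` gives 119 nM in an assay on isolated protein for inhibition of protein deacetylase HDAC6 (Homo sapiens), read by fluorescence, with stated times of 10 min and 2 h; a higher number here means a weaker inhibitor, a lower number a stronger inhibitor.
Compound 2 `Cc1ccc2ccccc2c1N1CC(=O)N(Cc2ccc(C(=O)NO)cc2)C1=O` gives 13.1 nM in this assay.
Compound 3 `CC1(c2ccccc2)NC(=O)N(Cc2ccc(C(=O)NO)cc2)C1=O` gives 74.9 nM in this assay.

Compound 3 stands second highest of the three numbers. Compound 1 sits within the usual scatter of it, so no order between those two can be claimed. Compound 2 gives a clearly lower number, beyond the scatter, and is the strongest inhibitor of the three. Compound 4 `O=C(NO)c1ccc(CN2C(=O)NC(CCc3ccccc3)(c3ccccc3)C2=O)cc1` is not yet measured; it differs from compound 3 by benzyl in place of hydrogen on a saturated chain carbon bound to a saturated ring carbon, which, cut one bond further out, reads methyl to phenethyl. Among the measured compounds shown here, with no measured step of this kind available, a modest move toward a lower number is expected, a 1.9-fold lower number from compound 3 to compound 4 (0.27 log units; within the scatter), resting on compound 2 and its 13.1 nM with a larger group on the shared core. Compound 4 is therefore estimated at 40 nM, within 12 nM to 130 nM.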

Compound 4, half-maximal inhibitory concentration: 24.7 nM
The estimate for compound 4 lay 1.6-fold (0.21 log units) above the measured number, within the range that was stated.
By their numbers in this assay, from the lowest: compounds 2 and 4 (each within the scatter of the next); then compounds 3 and 1 (each within the scatter of the next).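

Benzyl in place of hydrogen on a saturated chain carbon bound to a saturated ring carbon, read further out as methyl to phenethyl, gives a 3.0-fold lower number from compound 3 to compound 4 (0.48 log units; beyond the scatter) in this assay. Among the compounds shown here, this is the first single-place comparison in the set, and it shows that this position can carry the longer group with its added aromatic ring while the number falls. No measurement shown explains the gain. The compounds leave open whether that aromatic ring is needed, as a plain butyl chain would test, and how an amine or a carboxylic acid would read at this place.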